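A few compounds are considered here, and "the series" means these few. Any claim that something is new, unique, unknown or untested is made for them only; others in the source may bear on it.

In a functional assay on ECa-109 cells for inhibition, with ECa-109 cell line (Homo sapiens) as the target, read by sulforhodamine B assay (a lower number here means a stronger inhibitor, a higher number a weaker inhibitor), the three measured compounds give:

Compound 1 `O=C1C(Nc2cccc(Cl)c2)=CC(=O)c2c1nc1n2[C@H]2OC[C@@H](O)[C@H]2OC1` — 3080 nM
Compound 2 `O=C1C(N2CCCCC2)=CC(=O)c2c1nc1n2[C@H]2OC[C@@H](O)[C@H]2OC1` — a limit of the assay, > 8000 nM
Compound 3 `CCc1ccc(NC2=CC(=O)c3nc4n(c3C2=O)[C@H]2OC[C@@H](O)[C@H]2OC4)cc1` — 3080 nM

Compound 1 and compound 3 sit at the same number at the digits printed, so neither can be called stronger. Going by the values given here, compound 2 is reported only as a limit, and the one measured step, an at least 2.5-fold higher number from compound 1 to compound 2 (0.41 log units; beyond the scatter), shows that swapping the arylamino group for a saturated ring amine weakens inhibition (the limit of > 8000 nM in this assay, at which 1 of the 3 values shown sits).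

Compound 4 `CCOc1ccccc1NC1=CC(=O)c2c(nc3n2[C@H]2OC[C@@H](O)[C@H]2OC3)C1=O` keeps the arylamino group and changes only the ring on it: 2-ethoxyphenyl in place of 3-chlorophenyl on an amine nitrogen. Among the compounds with values here, no measured step follows exactly this kind of change. Within the data shown here, the only comparison of two aryl groups on the amine nitrogen is compound 1 against compound 3, whose values show no difference at the digits printed. The step to compound 2 replaces the whole aryl group and so says little about swapping one aryl for another.

On this basis compound 4 is expected to stay close to compound 1, a step of a 1.1-fold higher number from compound 1 to compound 4 (0.06 log units; within the scatter) at most, within the scatter. The estimate for compound 4 in this assay is 3500 nM, between 1500 nM and 8000 nM.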

Compound 4, half-maximal inhibitory concentration: 4320 nM
For compound 4 the middle estimate is 1.2-fold (0.09 log units) below the measured one; the range from low to high includes it.
By their numbers in this assay, from the lowest: compounds 1, 3 and 4 (each within the scatter of the next). At a limit, above all of these: compound 2.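

In this assay, the aryl group on the amine nitrogen can change from 3-chlorophenyl to 2-ethoxyphenyl without a clear effect, with a 1.4-fold higher number from compound 1 to compound 4 (0.15 log units; within the scatter). This is a larger change than the earlier pair of aryl groups might suggest: the chlorine is lost, the group goes from 7 to 9 heavy atoms, and it gains 1 hydrogen-bond acceptor, yet the step stays within the scatter. The measurements shown offer no explanation for why this exchange leaves the number so little changed.

Still open, from the compounds shown here alone, is whether an aryl ring carrying a carboxylic acid or a dimethylamino group would also stay level with compound 1. A benzyl group on the same nitrogen is also untested among the compounds shown, so it remains unknown whether keeping the ring but adding a carbon link would hold the value.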